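Methyl for Fluorine on the Cyclopropyl Amide

The source may report more compounds than this note shows. Statements on the series, on what has been measured and on what is new or still open speak of the compounds shown alone.

Compound 3 `O=C([C@@H]1C[C@H]1F)N1CC2CC(C1)N2` gives 110% in an assay on SH-EP1 cells for agonist activity at Neuronal acetylcholine receptor; alpha4/beta2 (Homo sapiens), read by FLIPR and calcium flux; a lower number here means a smaller maximal response, a higher number a larger maximal response. Compound 2 `CCCC(=O)N1CC2CC(C1)N2` gives 110%, and the two stand together at the top of the three numbers, with no change at the digits printed from compound 2 to compound 3 (within the scatter). Compound 1 `CC(=O)N1CC2CC(C1)N2` gives 95%, and a number 15 percentage points higher from compound 1 to compound 3 (beyond the scatter), much as a number 15 percentage points higher from compound 1 to compound 2 (beyond the scatter).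

Compound 4 `C[C@H]1C[C@H]1C(=O)N1CC2CC(C1)N2` arises through the change (2-methylcyclopropyl in place of 2-fluorocyclopropyl on a carbonyl carbon). Among the measured compounds shown here, no measured step makes this exact swap. The nearest guide is that a propyl and a 2-fluorocyclopropyl on the carbonyl carbon give the same response, so replacing the fluorine by a methyl within the same small ring is expected to leave this assay unchanged beyond the scatter, with no change at the digits printed from compound 3 to compound 4 (within the scatter). Compound 4 is therefore estimated at 110%, between 95% and 125%.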

Compound 4, largest response reached (Emax), in percent of the reference or control that the assay uses: 93%
The estimate for compound 4 lay 17 percentage points above the measured number; measured number below the stated range.
By their numbers in this assay, from the lowest: compounds 4 and 1 (each within the scatter of the next); then compounds 2 and 3 (each within the scatter of the next).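

In this assay, 2-methylcyclopropyl on the carbonyl carbon gives a number 17 percentage points lower from compound 3 to compound 4 (beyond the scatter) when it replaces 2-fluorocyclopropyl and a number 17 percentage points lower from compound 2 to compound 4 (beyond the scatter) when it replaces propyl, so at this position two groups with the same ring and the same heavy-atom count are not interchangeable. Replacing methyl with it gives a number 2 percentage points lower from compound 1 to compound 4 (within the scatter), so compound 4 goes against the gain over compound 1 seen with compound 2 and compound 3. Nothing available explains this difference. Still open, on these data alone, is how a plain cyclopropyl or a 2-aminocyclopropyl would behave at this position.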